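Chloro for bromo on compound 2: expectation for compound 3

This account rests on a few compounds, and the source may have more. Where it says the series, first, only, none or still open, it means among the compounds named here.

Compound 2 `O=C1C(Nc2ccc(Br)cc2)=CC(=O)c2ncncc21` stands level with compound 1 `O=C1C(Nc2ccccc2)=CC(=O)c2ncncc21`: in a functional assay on HCT-15 cells (Homo sapiens) for cytotoxicity, read by MTT assay, with a stated time of 72 h (on this read-out higher numbers stand for weaker inhibition and lower numbers for stronger inhibition), compound 2 gives 0.01 ug/mL, and compound 1 gives 0.01 ug/mL in this assay. For the measured compounds named here, the one step that bears on halogen at this position, no change at the digits printed from compound 1 to compound 2 (within the scatter), lay within the scatter. Compound 3 `O=C1C(Nc2ccc(Cl)cc2)=CC(=O)c2ncncc21` differs from compound 2 by chloro in place of bromo on an aromatic carbon. Since adding bromo gave no change, swapping it for chloro is expected to give none beyond the scatter either, so compound 3 is estimated at 0.01 ug/mL in this assay, with a range of 0.004 ug/mL to 0.025 ug/mL, a step of no change at the digits printed from compound 2 to compound 3 (within the scatter).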

Compound 3, half-maximal inhibitory concentration: < 0.01 ug/mL
Compound 3: only a limit was reported; the forecaster's own chance of this, stated with the estimate: 5%; the middle value lies on the limit itself.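

Compound 3 gives < 0.01 ug/mL in this assay, which is a limit and not a number. The steps are a number no higher from compound 2 to compound 3 (the limit leaves the size open) and a number no higher from compound 1 to compound 3 (the limit leaves the size open) and neither can be read for size, so chloro, bromo and hydrogen on this aromatic carbon cannot be ranked. What is new is that a second halogen at this place, para to a large group, also leaves the number no higher than for compound 1, and the series now reaches a limit: the limit of < 0.01 ug/mL in this assay, at which 1 of the 3 values shown sits.

As far as these compounds go, whether an amine or a carboxylic acid at this place would raise the number stays open. So does any real difference among the three compounds.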